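The source may report more compounds than this note shows. Statements on the series, on what has been measured and on what is new or still open speak of the compounds shown alone.

Measured in a functional assay on KB cells (Homo sapiens) for cytotoxicity, read by MTT assay, with a stated time of 72 h; a lower number here means a stronger inhibitor, a higher number a weaker inhibitor:
- compound 1 `Cc1ccc(S(=O)(=O)c2nc3ccccc3nc2N2CCCC2)cc1`: > 50000 nM
- compound 2 `Cc1ccc(S(=O)(=O)c2nc3ccccc3nc2N2CCc3ccccc3C2)cc1`: 32100 nM
- compound 3 `O=S(=O)(c1ccccc1)c1nc2ccccc2nc1N1CCC(O)CC1`: 5360 nM

The value of compound 1 is a limit, not a number. For the measured compounds named here, compound 3 gives 5360 nM, the lowest number in the set, and the only other number belongs to compound 2 at 32100 nM.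

Compound 4 `Cc1ccc(S(=O)(=O)c2nc3ccccc3nc2N2CCC(O)CC2)cc1` differs from compound 3 by methyl in place of hydrogen on an aromatic carbon, para to a large group, which takes phenyl to 4-methylphenyl: methyl in place of hydrogen on an aromatic carbon.

Going by the values given here, the only measured step, an at least 1.5-fold lower number from compound 1 to compound 2 (0.19 log units; that floor lies within the scatter), exchanges a different group and gives no direct size for this change. Compound 1 and compound 2 already carry 4-methylphenyl, but they differ from compound 4 elsewhere, so they do not isolate the methyl. Among the compounds with values here, with no measured step to suggest a shift in either direction in this assay, the expectation is anchored on compound 3 at 5360 nM. The expected change is a 1.1-fold higher number from compound 3 to compound 4 (0.05 log units; within the scatter), which means no step beyond the scatter. For compound 4 the estimated value is 6000 nM, with an expected range of 2000 nM to 18000 nM.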

Compound 4, half-maximal inhibitory concentration: 6140 nM
Beside the measured number, compound 4's estimate is 1.0-fold (0.01 log units) below it; the range from low to high includes it.
By their numbers in this assay, from the lowest: compounds 3 and 4 (each within the scatter of the next); then compound 2. At a limit, above all of these: compound 1.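

In this assay, the change from phenyl to 4-methylphenyl gives a 1.1-fold higher number from compound 3 to compound 4 (0.06 log units; within the scatter), so this methyl, para to a large group, leaves the number within the scatter. With 4-methylphenyl held constant, the exchange of the other group can now be read: 4-hydroxypiperidin-1-yl in place of 1,2,3,4-tetrahydroisoquinolin-2-yl gives a 5.2-fold lower number from compound 2 to compound 4 (0.72 log units; beyond the scatter). 4-hydroxypiperidin-1-yl in place of pyrrolidin-1-yl gives an at least 8.1-fold lower number from compound 1 to compound 4 (0.91 log units; beyond the scatter), a floor and not a size, as the value of compound 1 is a limit: the limit of > 50000 nM in this assay, at which 1 of the 4 values shown sits.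

Open, on these data alone, is what the hydroxyl of 4-hydroxypiperidin-1-yl contributes, a question that an unsubstituted piperidin-1-yl on the same sulfonyl-bearing core would address. Also open, as far as these compounds go, is whether a larger group at the para place, such as methoxy or a carboxylic acid, would stay within the scatter as methyl does.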